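A few compounds are considered here, and "the series" means these few. Any claim that something is new, unique, unknown or untested is made for them only; others in the source may bear on it.

The three measured compounds span a wide range in a functional assay on cells (Mus musculus) for antiproliferative activity, read by MTT assay; a higher number here means that more compound is needed for the effect, a lower number that less compound is needed. Compound 1, `Oc1ccc(CC[C@H]2CC=C[C@H](c3ccc(O)cc3)O2)cc1`, gives 71.2 uM in this assay, the highest of the three numbers. Compound 3, `COc1cc(O)c([C@@H]2C[C@H](CCc3ccc(O)cc3)O[C@H](c3ccc(O)cc3)[C@H]2[C@H](/C=C/C[C@@H](O)CCc2ccc(O)cc2)c2ccc(O)cc2)c(O)c1C(=O)/C=C/c1ccc(O)cc1`, gives 32.2 uM in this assay, a number below that of compound 1 by a margin beyond the scatter. Compound 2, `Oc1ccc(/C=C/[C@@H]2C[C@H](CCc3ccc(O)cc3)O[C@@H]3C[C@H](CCc4ccc(O)cc4)O[C@H](c4ccc(O)cc4)[C@@H]23)cc1`, gives 3.61 uM in this assay, the lowest of the three and far below compound 1. Among the compounds with values here, no pair of measured compounds differing in one place is available, so the change examined here stands on its own. Compound 4, `Oc1ccc(CC[C@H]2CC=C[C@@H](c3ccc(O)cc3)O2)cc1`, is the unmeasured partner of compound 1: the two compounds have the same atoms and bonds and differ only in configuration as drawn: 1 of 2 stereo elements differ; a stereocentre at a saturated ring carbon is drawn R in compound 1 and S in compound 4. The change is one of configuration only, and the account expects the step in this assay to be small, in either direction, and probably not beyond the scatter. Compound 4 is therefore estimated at 60 uM, with a range from 25 uM to 150 uM. The expected step is a 1.2-fold lower number from compound 1 to compound 4 (0.07 log units; within the scatter).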

Compound 4, concentration for half-maximal effect: > 100 uM
Compound 4 gave a limit, no number; the forecaster's own chance of this, stated with the estimate: 5%; middle value at least 1.6-fold (0.22 log units) from the limit.
By their numbers in this assay, from the lowest: compound 2; then compound 3; then compound 1. At a limit, above all of these: compound 4.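

In this assay compound 4 gives > 100 uM, which is a limit of the assay and not a number. The earlier compounds shown here offered no pair differing in one place, and this pair isolates a single stereocentre at a saturated ring carbon, with a step of an at least 1.4-fold higher number from compound 1 to compound 4 (0.14 log units; that floor lies within the scatter). Only a floor for that step can be read, so the result does not by itself establish a change beyond the scatter, but the comparison concerns configuration alone: the fact that compounds 1 and 4 differ only in the configuration as drawn.

From the compounds shown here alone, how large the true step is remains open, since compound 4 has no number. Also open, going by these compounds, is whether the two configurations would keep or lose this relation if a hydroxyl group of the shared core were replaced by an amine or a carboxylic acid.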